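Swapping an aminophenyl arm for a short amine chain

A few compounds are considered here, and "the series" means these few. Any claim that something is new, unique, unknown or untested is made for them only; others in the source may bear on it.

Measured compounds:
- compound 1, `Nc1ccc(Nc2c(C(=O)NCc3ccc(F)cc3)nc(Br)c3cccnc23)cc1`: 10000 nM
- compound 2, `N[C@H]1CC[C@H](Nc2c(C(=O)NCc3ccc(Cl)cc3Cl)nc(Br)c3cccnc23)CC1`: 6000 nM

Both compounds were tested in a functional assay on HCT-116 cells (Homo sapiens) for cytotoxicity, read by MTT assay, with a stated time of 72 h; on this read-out lower numbers stand for stronger inhibition and higher numbers for weaker inhibition. In this assay compound 1 gives 10000 nM, the highest of the two numbers recorded. Compound 2 gives 6000 nM, and the two values lie within the usual scatter of each other, so the data show no real difference between them. Compound 1 and compound 2 differ in more than one place, so no single step can be read from the pair.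

The next compound, compound 3, `CNCCCNc1c(C(=O)NCc2ccc(F)cc2)nc(Br)c2cccnc12`, has not yet been measured in this assay. Its relation to compound 1 is a single change: 3-(methylamino)propyl in place of 4-aminophenyl on a nitrogen on an aromatic ring. The shared core, the bromine on it and the fluorobenzyl amide are kept, and only the group on the ring nitrogen is exchanged for the 3-(methylamino)propyl chain.

For the measured compounds named here, no measured pair tells how such a change behaves here, so the expectation rests only on the two values above. For compound 3 the step from compound 1 is expected to be a 1.4-fold lower number from compound 1 to compound 3 (0.15 log units; within the scatter), that is, no change beyond the scatter. Compound 3 is therefore estimated at 7000 nM, within a range from 1500 nM to 20000 nM.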

Compound 3, half-maximal inhibitory concentration: 9000 nM
The estimate for compound 3 lay 1.3-fold (0.11 log units) below the measured number; the measured number falls inside the stated range.
By their numbers in this assay, from the lowest: compounds 2, 3 and 1 (each within the scatter of the next).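

In this assay, for the compounds shown here, exchanging 4-aminophenyl for 3-(methylamino)propyl on a nitrogen on an aromatic ring gives a 1.1-fold lower number from compound 1 to compound 3 (0.05 log units; within the scatter), the first comparison here in which only one place differs. At this position, then, an arm with a six-membered aromatic ring of carbon and a chain with no ring cannot be told apart on this read-out, even though the two groups differ in shape and in their number of heavy atoms. Nothing measured alongside these cell numbers offers an explanation for this result.

The compounds shown leave open whether a carboxylic acid, a longer amine chain or a saturated ring amine on this nitrogen, with the fluorobenzyl amide kept, would move the number beyond the scatter, and whether the exchange seen here would read the same with a different benzyl group on the amide. Compound 2 differs from both compound 1 and compound 3 in more than one place, so its steps to them cannot be read.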